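Trading a Methoxy Group for a Methyl Group

A few compounds are considered here, and "the series" means these few. Any claim that something is new, unique, unknown or untested is made for them only; others in the source may bear on it.

Of the compounds shown here, three built on one shared core have been measured in an assay on microsomes from liver for inhibition of 3-hydroxy-3-methylglutaryl-coenzyme A reductase (Rattus norvegicus), read by scintillation counting, with stated times of 0.5 h and 0.75 h; on this read-out lower numbers stand for stronger inhibition and higher numbers for weaker inhibition. Compound 1 `COc1ccc(CNC(=O)c2nc(-c3ccc(F)cc3)n(CC[C@@H](O)C[C@@H](O)CC(=O)O)c2C2CC2)cc1F` gives 3.7 nM. Compound 2 `COc1ccc(CNC(=O)c2nc(-c3ccc(F)cc3)n(CC[C@@H](O)C[C@@H](O)CC(=O)O)c2C2CC2)cc1` gives 1.2 nM, and compound 3 `Cc1cccc(CNC(=O)c2nc(-c3ccc(F)cc3)n(CC[C@@H](O)C[C@@H](O)CC(=O)O)c2C2CC2)c1` gives 7.2 nM. Compound 2 has the lowest number of the three, since the step of a 3.1-fold lower number from compound 1 to compound 2 (0.49 log units; beyond the scatter) and the step of a 6.0-fold higher number from compound 2 to compound 3 (0.78 log units; beyond the scatter) both lie beyond the scatter. Compound 1 and compound 3 sit closer to each other, with a 1.9-fold higher number from compound 1 to compound 3 (0.29 log units; within the scatter).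

Compound 4 `Cc1ccccc1CNC(=O)c1nc(-c2ccc(F)cc2)n(CC[C@@H](O)C[C@@H](O)CC(=O)O)c1C1CC1` has not yet been measured in this assay. Relative to compound 2 it carries a single change: 2-methylphenyl in place of 4-methoxyphenyl on a saturated chain carbon bound to an amide-type nitrogen. The measured step that speaks most directly to this change is a 6.0-fold higher number from compound 2 to compound 3 (0.78 log units; beyond the scatter), where 3-methylphenyl replaced 4-methoxyphenyl at the same place. Among the compounds with values here, no measured pair shows whether 2-methylphenyl behaves like 3-methylphenyl, so the expectation rests on that one step, with a wider range to allow for the difference between the two methylphenyl groups. The expected step is a 5.0-fold higher number from compound 2 to compound 4 (0.70 log units; beyond the scatter), a weakening beyond the scatter. Compound 4 is therefore estimated at 6 nM, with a range from 2 nM to 20 nM.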

Compound 4, half-maximal inhibitory concentration: 4.9 nM
Compound 4: the middle estimate sits 1.2-fold (0.09 log units) above what was measured; measured number inside the range.
By their numbers in this assay, from the lowest: compound 2; then compounds 1, 4 and 3 (each within the scatter of the next).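

In this assay, the step of a 4.1-fold higher number from compound 2 to compound 4 (0.61 log units; beyond the scatter) shows that 2-methylphenyl, like 3-methylphenyl, gives a weaker result than 4-methoxyphenyl on this saturated chain carbon, so compound 2 now stands apart from both methylphenyl compounds. Exchanging one methylphenyl group for the other makes no difference that can be told apart, with a 1.5-fold lower number from compound 3 to compound 4 (0.17 log units; within the scatter) within the scatter, and the comparison with the 3-fluoro-4-methoxyphenyl group is just as close, with a 1.3-fold higher number from compound 1 to compound 4 (0.12 log units; within the scatter) also within the scatter. Nothing at hand bears on why 4-methoxyphenyl gives the lowest number of these groups.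

The compounds shown leave open whether the low number of compound 2 goes with the methoxy group itself or with where that group sits on the ring, a question that 4-methylphenyl and 2-methoxyphenyl at this place could help to settle. They also leave open how a plain phenyl ring, or a ring carrying a hydroxy group or an amine, would compare with these groups.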